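A Methyl on the Chain Carbon of Compound 1

A few compounds are considered here, and "the series" means these few. Any claim that something is new, unique, unknown or untested is made for them only; others in the source may bear on it.

In an ADME assay on MT4 cells (Homo sapiens) for activation, read by MTT assay (on this read-out lower numbers stand for higher toxicity in this test and higher numbers for lower toxicity in this test), compound 1 (`CC(C)Sc1nc(Cc2c(F)cccc2Cl)cc(=O)[nH]1`) gives > 80000 nM, which is a limit and not a number. Compound 2 (`Cc1c(Cc2c(F)cccc2Cl)nc(SC(C)C)[nH]c1=O`) gives > 76000 nM, which is also a limit. Among the measured compounds shown here, the only measured step, a step that the two limits leave unreadable from compound 1 to compound 2, places a methyl on an aromatic carbon, so it offers no readable size. Compound 3 (`CC(C)Sc1nc(C(C)c2c(F)cccc2Cl)cc(=O)[nH]1`) differs from compound 1 by methyl in place of hydrogen on a saturated chain carbon bound to two aromatic carbons, with methyl in place of hydrogen on a saturated chain carbon bound to two aromatic carbons. No step beyond the scatter is therefore expected, and the expected change is an at least 1.1-fold lower number from compound 1 to compound 3 (0.05 log units; that floor lies within the scatter). Compound 3 is estimated at 70000 nM, with an expected range from 25000 nM to 120000 nM.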

Compound 3, half-maximal cytotoxic concentration: > 75000 nM
Compound 3 ended at the assay's limit; the forecaster's own chance of this, stated with the estimate: 65%; at least 1.0-fold (0.02 log units) between middle value and limit.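

Compound 3, like compound 1, stands at a limit of this assay, so no step can be read between compound 1 and compound 3. The compounds shown leave open how toxic any of them becomes at higher concentrations.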